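Methyl on the Pyrrolidine Ring of Compound 1

The compounds below may be only part of what the source reports. "The series", "measured", "known", "first", "only" and "open" are said of these compounds alone.

Within the data shown here, compound 1 `Cn1c(N2CCCC2)c(C#N)c2c(N)ncnc21` was tested in an assay on isolated protein for binding affinity to Leucine-rich repeat serine/threonine-protein kinase 2 (Homo sapiens), read by TR-FRET and LanthaScreen, with a stated time of 2 h (a higher number here means a weaker inhibitor, a lower number a stronger inhibitor), and gives 41 nM, the second highest of the three numbers known. Among the measured compounds shown here, compound 2 `C[C@@H]1CCCN1c1c(C#N)c2c(N)nccc2n1C` gives 0.8 nM in this assay, and compound 3 `C[C@@H]1CCCN1c1c(C#N)c2c(N)nc(Nc3cnn(C)c3)cc2n1C` gives 538 nM; the only measured single change, a 670-fold higher number from compound 2 to compound 3 (2.83 log units; beyond the scatter), concerns a different part of the molecule and does not bear on the step here. Compound 4 `C[C@@H]1CCCN1c1c(C#N)c2c(N)ncnc2n1C` differs from compound 1 by methyl in place of hydrogen on a saturated ring carbon. For the measured compounds named here, no measured step isolates this change; compound 2 carries the same 2-methylpyrrolidin-1-yl group on a different core and shows a much lower number than compound 1. Compound 4 is therefore expected to give 10 nM, between 3 nM and 40 nM, a moderate gain estimated as a 4.1-fold lower number from compound 1 to compound 4 (0.61 log units; beyond the scatter).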

Compound 4, inhibition constant: 0.4 nM
Estimate against measurement, compound 4: 25-fold (1.40 log units) above; measured number below the stated range.
By their numbers in this assay, from the lowest: compounds 4 and 2 (each within the scatter of the next); then compound 1; then compound 3.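

A single methyl in place of hydrogen, on a saturated ring carbon next to the ring nitrogen, brings a 100-fold lower number from compound 1 to compound 4 (2.01 log units; beyond the scatter) in this assay. Among these compounds, this is the first measured step at this position, and it shows that one added carbon here is enough for a large change on the core of compound 1. Nothing shown gives a reason for the size of this step. Open, as far as these compounds go, is how larger groups in the same place, such as ethyl or hydroxymethyl, would compare with methyl, and how the mirror-image 2-methylpyrrolidin-1-yl group would compare.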